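A few compounds are considered here, and "the series" means these few. Any claim that something is new, unique, unknown or untested is made for them only; others in the source may bear on it.

Working notes on the series. In a functional assay on SF-295 cells (Homo sapiens) for inhibition, read by sulforhodamine B assay, with a stated time of 48 h (on this read-out higher numbers stand for lower toxicity in this test and lower numbers for higher toxicity in this test), compound 1 `O=C(Nc1cccc(-n2cc(-c3ccncc3)c(-c3ccc(Cl)c(O)c3)n2)c1)Nc1cccc(C(F)(F)F)c1` gives 29200 nM, while compound 2 `COc1cc(-c2nn(-c3cccc(NC(=O)Nc4cc(C(F)(F)F)cc(C(F)(F)F)c4)c3)cc2-c2ccncc2)ccc1Cl` gives 3310 nM. Compound 2 thus stands at the lowest of the two numbers in this assay, and the gap to compound 1 lies beyond the scatter. For the measured compounds named here, no pair measured so far differs in only one place, so the two values of compound 1 and compound 2 are all that can be said of them together.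

Compound 3 `O=C(Nc1cccc(-n2cc(-c3ccncc3)c(-c3ccc(Cl)c(O)c3)n2)c1)Nc1cc(C(F)(F)F)cc(C(F)(F)F)c1` has not been measured. It differs from compound 2 in one place: hydrogen in place of methyl on an oxygen on an aromatic ring. Compound 3 shares the hydroxy arrangement of compound 1 and the bis-trifluoromethyl arrangement of compound 2, so neither value gives a direct guide. The step is expected to be modest and upward, that is toward weaker toxicity in this assay, because compound 1 with the hydroxy group gives 29200 nM. The step from compound 2 to compound 3 is estimated at a 2.4-fold higher number from compound 2 to compound 3 (0.38 log units; beyond the scatter). Compound 3 is expected to give about 8000 nM, with a range from 2500 nM to 25000 nM.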

Compound 3, concentration lethal to 50% of the cells: 4390 nM
For compound 3 the middle estimate is 1.8-fold (0.26 log units) above the measured one; the range from low to high includes it.
By their numbers in this assay, from the lowest: compounds 2 and 3 (each within the scatter of the next); then compound 1.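

Going from methoxy to hydroxy gives a 1.3-fold higher number from compound 2 to compound 3 (0.12 log units; within the scatter), so in this assay this position shows no readable response to the change while the bis-trifluoromethyl arrangement is present. Trifluoromethyl in place of hydrogen on an aromatic carbon gives a 6.7-fold lower number from compound 1 to compound 3 (0.82 log units; beyond the scatter), so with the hydroxy group held constant, this second place accounts for a gap beyond the scatter, which the two-place comparison of compound 1 and compound 2 could not show. Nothing available explains either step.

As far as these compounds go, it remains open whether a longer chain such as ethyl on that oxygen, or an amine in place of the hydroxy group, would stay within the scatter of compound 2. From the compounds shown here alone, it is also open whether methoxy to hydroxy would give the same small step with hydrogen in place of the second trifluoromethyl.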